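A Chlorine Swap on a Weak Amide Inhibitor

This account rests on a few compounds, and the source may have more. Where it says the series, first, only, none or still open, it means among the compounds named here.

This set of three amides was tested in an assay on HEK293 cells for inhibition of N-acylethanolamine-hydrolyzing acid amidase (Rattus norvegicus), read by LC-MS, with a stated time of 30 min; a lower number here means a stronger inhibitor, a higher number a weaker inhibitor. Compound 1 `Cc1ccc(CCCCCCC(=O)N2CCCC2)cc1` gives 9600 nM in this assay. Compound 2 `O=C(CCCCCCc1ccccc1Cl)N1CCCC1` reaches only the limit of the assay, > 100000 nM, and no number. Compound 3 `Cc1ccccc1-c1ccc(CCC(=O)N2CCCC2)cc1` likewise gives only a limit, > 100000 nM. So compound 3 stands at the limit of > 100000 nM in this assay, at which 2 of the 3 values shown sit, the point where the assay stops reporting a number, and it shares that place with compound 2; only compound 1 shows a measured value. Compound 4 `O=C(CCc1ccc(-c2ccc(Cl)cc2)cc1)N1CCCC1` has not yet been measured. It differs from compound 3 in one place: 4-chlorophenyl in place of 2-methylphenyl on an aromatic carbon. Among the compounds with values here, no measured pair shows what such a change does here, so the expected direction rests on the weak starting point alone. From a compound sitting at the limit, the step from compound 3 to compound 4 is estimated as an at least 2.0-fold lower number from compound 3 to compound 4 (0.30 log units; that floor lies within the scatter), a modest gain at best. Compound 4 is therefore expected to give about 50000 nM, within a range from 10000 nM to 200000 nM, with a real chance that the assay again returns only a limit.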

Compound 4, half-maximal inhibitory concentration: 48600 nM
Compound 4: the middle estimate sits 1.0-fold (0.01 log units) above what was measured, and the stated range covers the measured number.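

Putting 4-chlorophenyl in place of 2-methylphenyl on this aromatic carbon gives an at least 2.0-fold lower number from compound 3 to compound 4 (0.31 log units; beyond the scatter), the only step at this position that can be read among these compounds. The earlier compounds shown here showed no effect of any change here, whereas this result shows that the group on this carbon can move the read-out from a limit to a measured number. The true size of the step remains unknown, and the printed figure is only a floor, because the entry for compound 3 is a limit and not a number: the limit of > 100000 nM in this assay, at which 2 of the 4 values shown sit.

The swap alters both the atom on the ring and its place, so the two effects cannot be separated here. As far as these compounds go, it also remains open how a 4-methylphenyl or 2-chlorophenyl group, a carboxylic acid on this ring, or a longer chain before the amide carbonyl would read.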